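Adding a hydroxy to the phenyl of compound 3

This account rests on a few compounds, and the source may have more. Where it says the series, first, only, none or still open, it means among the compounds named here.

Compound 1 `CC1=C(c2ccc(C#N)cc2)C(c2ccc(OC[C@H](C)N3CC[C@@H](C)C3)cc2)Oc2ccc(O)cc21`: 10 nM
Compound 2 `CC1=C(c2cccc(O)c2)C(c2ccc(OC[C@H](C)N3CC[C@@H](C)C3)cc2)Oc2ccc(O)cc21`: 0.2 nM
Compound 3 `CC1=C(c2ccccc2)C(c2ccc(OC[C@H](C)N3CC[C@@H](C)C3)cc2)Oc2ccc(O)cc21`: 0.4 nM

In a functional assay on MCF7 cells (Homo sapiens) for antiproliferative activity, read by CellTiter-Glo, with a stated time of 5 days (a higher number here means a weaker inhibitor, a lower number a stronger inhibitor), compound 3 gives 0.4 nM, which lies within the scatter of compound 2 and far below compound 1. The next compound, compound 4 `CC1=C(c2ccc(O)cc2)C(c2ccc(OC[C@H](C)N3CC[C@@H](C)C3)cc2)Oc2ccc(O)cc21`, differs from compound 3 in one place: hydroxy in place of hydrogen on an aromatic carbon, which turns phenyl into 4-hydroxyphenyl (hydroxy in place of hydrogen on an aromatic carbon). Among the measured compounds shown here, no measured compound carries a hydroxy on that carbon, so two related steps have to serve as a guide. Removing the hydroxy from the 3-hydroxyphenyl ring gives a 2.0-fold higher number from compound 2 to compound 3 (0.30 log units; within the scatter), so a hydroxy elsewhere on this ring made no clear difference. The 4-cyanophenyl ring holds cyano at the place that changes here, and hydrogen in place of cyano gives a 25-fold lower number from compound 1 to compound 3 (1.40 log units; beyond the scatter). That large step shows that a group at this place can matter, but it involves cyano, not hydroxy. The expectation in this assay is therefore no step beyond the scatter, with some risk of a higher number. Compound 4 is estimated at 0.3 nM, with an expected range of 0.1 nM to 1 nM. This estimate means an expected 1.3-fold lower number from compound 3 to compound 4 (0.12 log units; within the scatter).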

Compound 4, half-maximal inhibitory concentration: 0.1 nM
For compound 4 the middle estimate is 3.0-fold (0.48 log units) above the measured one; measured number inside the range.
By their numbers in this assay, from the lowest: compounds 4, 2 and 3 (each within the scatter of the next, the first and the last beyond it); then compound 1.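

In this assay, hydroxy on the aromatic carbon para to a large group has a measurable effect: replacing hydrogen with it gives a 4.0-fold lower number from compound 3 to compound 4 (0.60 log units; beyond the scatter) and this modest step lies beyond the scatter, unlike the earlier step between the 3-hydroxyphenyl and phenyl rings. The two hydroxy rings still cannot be told apart, since changing 3-hydroxyphenyl to 4-hydroxyphenyl gives a 2.0-fold lower number from compound 2 to compound 4 (0.30 log units; within the scatter) and so shows no clear preference for either ring. The group on this one carbon can matter greatly, as hydroxy in place of cyano gives a 100-fold lower number from compound 1 to compound 4 (2.00 log units; beyond the scatter) and this is the widest step in the series, with hydrogen and hydroxy both far below cyano.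

The data offer no measurement that explains these steps. The compounds shown leave open whether another group on this carbon, such as methoxy, an amine or a carboxylic acid, would fall near hydroxy or near cyano.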